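Replacing a Methoxycyclohexyl Ring with a Carbamoyl Cyclobutyl Ring

The source may report more compounds than this note shows. Statements on the series, on what has been measured and on what is new or still open speak of the compounds shown alone.

Measured so far:
compound 1, `N#Cc1cnc(NCc2ccccc2C(F)(F)F)cc1N[C@H]1CC[C@@H](O)CC1`: 140 nM
compound 2, `CO[C@H]1CC[C@H](Nc2cc(NCc3cnccc3C(F)(F)F)ncc2C#N)CC1`: 1100 nM
compound 3, `CC1(C)[C@H](O)C[C@H]1Nc1nc(NCc2cnccc2C(F)(F)F)ncc1C#N`: 130 nM

In an assay on isolated protein for inhibition of protein kinase C theta type (Homo sapiens), read by TR-FRET, with a stated time of 2 h (a lower number here means a stronger inhibitor, a higher number a weaker inhibitor), compound 2 gives the highest number of the three, so it is the weakest inhibitor here. Compound 1, at 140 nM, and compound 3, at 130 nM, both sit lower by more than the usual scatter.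

Compound 4, `CC1(C)[C@@H](Nc2cc(NCc3cnccc3C(F)(F)F)ncc2C#N)C[C@@H]1C(N)=O`, is not yet measured. Its change from compound 2 is 3-carbamoyl-2,2-dimethylcyclobutyl in place of 4-methoxycyclohexyl on a nitrogen on an aromatic ring. Among the compounds with values here, no measured pair shows this change on its own. Compound 3 also carries a small dimethylcyclobutyl ring and is among the lower values, so a downward step beyond the scatter is expected. The estimated value for compound 4 is 300 nM, with a range from 100 nM to 900 nM. This expected change amounts to a 3.7-fold lower number from compound 2 to compound 4 (0.56 log units; beyond the scatter).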

Compound 4, half-maximal inhibitory concentration: 1100 nM
Estimate against measurement, compound 4: 3.7-fold (0.56 log units) below; the measured number lies above the stated range.
By their numbers in this assay, from the lowest: compounds 3 and 1 (each within the scatter of the next); then compounds 2 and 4 (each within the scatter of the next).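

In this assay, 3-carbamoyl-2,2-dimethylcyclobutyl in place of 4-methoxycyclohexyl on a nitrogen on an aromatic ring gives no change at the digits printed from compound 2 to compound 4 (within the scatter). A dimethylcyclobutyl ring is therefore not enough on its own to give a lower number at this position, and the two quite different groups read alike here. Nothing measured explains this result.

Still open, from the compounds shown here alone, is whether a carboxylic acid or an amine in place of the carbamoyl group on the same ring would shift the number. Going by these compounds, the separate contributions of the four-membered ring and the carbamoyl group also remain unknown, since they enter together in this step.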